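Replacing a nitrophenyl with a pyridinyl in an inactive series

This account rests on a few compounds, and the source may have more. Where it says the series, first, only, none or still open, it means among the compounds named here.

Compound 3 `O=[N+]([O-])c1ccc(N2CCN(Cn3nc(-c4ccc5c(c4)OCCO5)oc3=S)CC2)cc1` is one of three close relatives tested for antiproliferative activity. In a functional assay on SW 1116 cells (Homo sapiens) for antiproliferative activity, read by MTT assay, with a stated time of 48 h (a lower number here means a stronger inhibitor, a higher number a weaker inhibitor), compound 3 gives only a limit of the assay, > 50000 nM. Compound 1 `S=c1oc(-c2ccc3c(c2)OCCO3)nn1CN1CCN(c2ccccc2)CC1` likewise gives only a limit, > 50000 nM. Compound 2 `Fc1ccc(N2CCN(Cn3nc(-c4ccc5c(c4)OCCO5)oc3=S)CC2)cc1` also gives only a limit, > 50000 nM. The steps a step that the two limits leave unreadable from compound 1 to compound 2, a step that the two limits leave unreadable from compound 1 to compound 3 and a step that the two limits leave unreadable from compound 2 to compound 3 cannot be sized because of the limit of > 50000 nM in this assay, at which 3 of the 3 values shown sit. Compound 4 `S=c1oc(-c2ccc3c(c2)OCCO3)nn1CN1CCN(c2ccccn2)CC1` differs from compound 3 by pyridin-2-yl in place of 4-nitrophenyl on an amine nitrogen in a ring. Among the compounds with values here, none of the measured steps reads on this change, so no shift beyond the scatter is expected in this assay . Compound 4 is therefore estimated at 70000 nM, within 20000 nM to 300000 nM, most likely again reported as a limit. The expected step that the limit leaves unreadable from compound 3 to compound 4 is thus small.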

Compound 4, half-maximal inhibitory concentration: 9490 nM
Compound 4: middle estimate off by 7.4-fold (0.87 log units), on the high side; the measured number lies below the stated range.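

Pyridin-2-yl on the amine nitrogen in the ring gives the first value in this series that is a number rather than a limit: the step is an at least 5.2-fold lower number from compound 3 to compound 4 (0.72 log units; beyond the scatter) against 4-nitrophenyl, an at least 5.2-fold lower number from compound 2 to compound 4 (0.72 log units; beyond the scatter) against 4-fluorophenyl and an at least 5.2-fold lower number from compound 1 to compound 4 (0.72 log units; beyond the scatter) against phenyl. The true size of each step remains open, as each starts from a limit: the limit of > 50000 nM in this assay, at which 3 of the 4 values shown sit.

The steps among the three earlier compounds cannot be read. Also open is whether the ring nitrogen must sit as it does in pyridin-2-yl, as pyridin-3-yl, pyridin-4-yl and pyrimidin-2-yl are absent from the compounds shown.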